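The source may report more compounds than this note shows. Statements on the series, on what has been measured and on what is new or still open speak of the compounds shown alone.

Measured compounds in a functional assay on HEK293 cells for agonist activity at Glucose-dependent insulinotropic receptor (Homo sapiens), read by cAMP accumulation, with a stated time of 60 min; a lower number here means that less compound is needed, a higher number that more compound is needed for the effect:
- compound 1 `CCCS(=O)(=O)N1CC=C(c2ccc3c(c2)CC(C2CCN(Cc4ccccc4)CC2)O3)CC1`: 521 nM
- compound 2 `CCCS(=O)(=O)N1CC=C(c2ccc3c(c2)CC(C2CCN(C(=O)OC(C)C)CC2)O3)CC1`: 103 nM
- compound 3 `CCCS(=O)(=O)N1CC=C(c2ccc3c(c2)CC(C2CCN(S(=O)(=O)CCC)CC2)O3)CC1`: 1000 nM

All three share one core and differ only in the group on an amine nitrogen in a ring. Compound 3 has the highest number of the three in this assay; its gap to compound 1 is within the scatter, so the two cannot be ranked, while a 9.7-fold higher number from compound 2 to compound 3 (0.99 log units; beyond the scatter) is a clear worsening. Compound 4 `CCCS(=O)(=O)N1CC=C(c2ccc3c(c2)CC(C2CCN(C(=O)OC4CCCCC4)CC2)O3)CC1` is not yet measured. Its change is cyclohexyloxycarbonyl in place of propylsulfonyl on an amine nitrogen in a ring. The step that bears on it most is the reverse of a 9.7-fold higher number from compound 2 to compound 3 (0.99 log units; beyond the scatter), since both isopropoxycarbonyl and cyclohexyloxycarbonyl are carbamate-type groups and the sulfonyl leaves. A further hint comes from a 5.1-fold lower number from compound 1 to compound 2 (0.70 log units; beyond the scatter). Among the measured compounds shown here, the expectation is therefore a lower number in this assay, with a 7.7-fold lower number from compound 3 to compound 4 (0.89 log units; beyond the scatter) likely, though the larger ring has no measured precedent here. Compound 4 is estimated at 130 nM, in the range 40 nM to 400 nM.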

Compound 4, half-maximal effective concentration: 51 nM
Estimate against measurement, compound 4: 2.5-fold (0.41 log units) above; the measured number falls inside the stated range.
By their numbers in this assay, from the lowest: compound 4; then compound 2; then compounds 1 and 3 (each within the scatter of the next).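

In this assay, among the compounds shown here, the group on the amine nitrogen in a ring turns out to have more range than the earlier compounds showed, with cyclohexyloxycarbonyl replacing propylsulfonyl giving a large step (a 20-fold lower number from compound 3 to compound 4 (1.29 log units; beyond the scatter)). The part of the group beyond the oxygen also counts, not just the carbonyl: cyclohexyl in place of isopropyl gives a modest step (a 2.0-fold lower number from compound 2 to compound 4 (0.31 log units; beyond the scatter)). Compound 4 also has a large step against the benzyl group (a 10-fold lower number from compound 1 to compound 4 (1.01 log units; beyond the scatter)), so its steps to all three other compounds lie beyond the scatter and it has the lowest number of the four.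

Nothing given here explains why these numbers move. On these data alone, it also remains open whether a cyclopentyl or phenyl group on that oxygen would lower the number further, or how an amide or a urea would compare with the carbamate-type groups.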